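The source may hold more compounds than are shown below. What is called first, only, known or untested is meant among the compounds shown, and "the series" means these compounds.

Measured so far:
- compound 1, `C=CCc1cc(C(C)=O)c(O)cc1OCCCCCC#N`, 41% in an assay on isolated protein for binding affinity to leukotriene B4 receptor 1 (Homo sapiens), tested at 1 uM; on this read-out higher numbers stand for more inhibition at the one concentration tested (going by the name of the read-out) and lower numbers for less inhibition
- compound 2, `CCc1cc(C(C)=O)c(O)cc1OCCCC(C)(C)C#N`, 46%

Compound 1 gives the lower of the two numbers in this assay, and its nearest neighbour is compound 2, whose value lies only a few points higher, a gap that falls within the usual scatter of repeated measurements. The two results therefore read as alike, and neither number can be called the higher one on this evidence.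

The step under consideration leads from compound 1 to compound 3, `C=CCc1cc(C(C)=O)c(O)cc1OCCCCO`, which has not yet been measured in this assay. The change is hydroxy in place of cyanomethyl on a saturated chain carbon, four bonds along the chain from an oxygen on an aromatic ring. Among the compounds with values here, no measured pair in this set shows this kind of exchange, so there is no direct precedent for how large a step it brings.

Within the data shown here, with only two measured values, both alike, the expectation for compound 3 rests mainly on the size of the change itself. A moderate downward step of a number 11 percentage points lower from compound 1 to compound 3 (beyond the scatter) is expected, and the estimate for compound 3 is 30%, in a range from 8% to 55%.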

Compound 3, a percentage reported as inhibition, at one concentration (the size of the read-out at that concentration, not a potency): 9%
Compound 3: the middle estimate sits 21 percentage points above what was measured; the range from low to high includes it.
By their numbers in this assay, from the lowest: compound 3; then compounds 1 and 2 (each within the scatter of the next).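

Exchanging the cyanomethyl group for hydroxy on a saturated chain carbon, four bonds along the chain from an oxygen on an aromatic ring, gives a number 32 percentage points lower from compound 1 to compound 3 (beyond the scatter) in this assay. This shows that the outer part of the chain is not a free spot in this read-out: with the core of compound 1 left unchanged, altering this one place moves the number well beyond the usual scatter, something compounds 1 and 2 could not show, as they differ in more than one place. No measurement here explains the drop, so the result records only its size and direction.

The single step also shortens the chain and replaces its end group at once, since it can equally be read as 4-cyanobutyl to 3-hydroxypropyl, so the compounds shown cannot separate the loss of chain length from the loss of the nitrile. A nitrile on a shorter chain, a hydroxy on a longer chain, or an amine or a carboxylic acid at the chain end would each help to tell these two parts of the change apart.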